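Series notes: indolyl for phenyl on the carbonyl

The source may report more compounds than this note shows. Statements on the series, on what has been measured and on what is new or still open speak of the compounds shown alone.

Measured compounds:
compound 1, `Fc1ccc(C(SCCNC2CCN(Cc3ccc(C(F)(F)F)cc3)CC2)c2ccc(F)cc2)cc1`: 186 nM
compound 2, `OC(Cc1ccccc1)CN1CCC(NCCSC(c2ccc(F)cc2)c2ccc(F)cc2)CC1`: 309 nM
compound 3, `O=C(c1ccccc1)N1CCC(NCCSC(c2ccc(F)cc2)c2ccc(F)cc2)CC1`: 2.03 nM

All three share one core and differ only in the group on the ring nitrogen. In an assay on membranes from Cortex for displacement of a labelled ligand from Sigma non-opioid intracellular receptor 1 (Cavia porcellus), read by scintillation counting, with a stated time of 120 min (on this read-out lower numbers stand for stronger inhibition and higher numbers for weaker inhibition), compound 1 and compound 2 sit close together, with a 1.7-fold higher number from compound 1 to compound 2 (0.22 log units; within the scatter). Compound 3 stands lowest of the three numbers: a 92-fold lower number from compound 1 to compound 3 (1.96 log units; beyond the scatter) and a 150-fold lower number from compound 2 to compound 3 (2.18 log units; beyond the scatter) are both large steps beyond the scatter, so compound 3 is the strongest binder of the three.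

Compound 4, `O=C(c1cc2ccccc2[nH]1)N1CCC(NCCSC(c2ccc(F)cc2)c2ccc(F)cc2)CC1`, keeps the carbonyl on the ring nitrogen and changes only the group on that carbonyl carbon: 1H-indol-2-yl in place of phenyl on a carbonyl carbon. Going by the values given here, none of the measured steps touches this position; all three concern the group on the ring nitrogen itself, so there is no measured precedent for the size or direction of this change in this assay. The expectation therefore rests on compound 3 alone, because compound 3 gives 2.03 nM and the benzoyl-type amide is retained. No step beyond the scatter is expected, read as a 1.5-fold higher number from compound 3 to compound 4 (0.17 log units; within the scatter) in this assay.

Compound 4 is estimated at 3 nM. The range for compound 4 is expected to run from 0.7 nM to 12 nM.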

Compound 4, inhibition constant: 1130 nM
For compound 4 the middle estimate is 380-fold (2.58 log units) below the measured one; the measured number lies above the stated range.
By their numbers in this assay, from the lowest: compound 3; then compounds 1 and 2 (each within the scatter of the next); then compound 4.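

In this assay the group on the carbonyl carbon turns out to be a highly sensitive position, which the earlier changes on the ring nitrogen could not show: 1H-indol-2-yl in place of phenyl gives a 560-fold higher number from compound 3 to compound 4 (2.75 log units; beyond the scatter). Retaining the carbonyl on the ring nitrogen is therefore not enough to keep the low number of compound 3, and the (1H-indol-2-yl)carbonyl group also falls behind both groups without a carbonyl, with a 3.7-fold higher number from compound 2 to compound 4 (0.56 log units; beyond the scatter) and a 6.1-fold higher number from compound 1 to compound 4 (0.78 log units; beyond the scatter). No available evidence bears on the reason for this loss.

The compounds shown leave open whether the loss follows the added ring atoms or the hydrogen-bond donor of 1H-indol-2-yl. A naphthalen-2-yl group on the carbonyl carbon, or a 1-methylindol-2-yl group, would separate the two.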